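Plasma half-life in the amine-substituted series: compound 4

The source may report more compounds than this note shows. Statements on the series, on what has been measured and on what is new or still open speak of the compounds shown alone.

Measured so far in an ADME assay on a cell-free system (plasma, Mus musculus) for metabolic stability, read by LC-MS, tested at 2 uM; a higher number here means that the compound lasts longer, a lower number that the compound disappears faster:
- compound 1 `CN1CCN(c2ccc3c(c2)oc(=O)n3C(=O)NCCCCc2ccccc2)CC1=O`: 0.333 h
- compound 2 `CN1CCC(c2ccc3c(c2)oc(=O)n3C(=O)NCCCCc2ccc(F)cc2)CC1`: 0.333 h
- compound 3 `CC(C)CN1CCC(c2ccc3c(c2)oc(=O)n3C(=O)NCCCCc2ccccc2)CC1`: 1 h

Compound 3 gives the highest of the three numbers in this assay. For the measured compounds named here, the one step that reaches it, a 3.0-fold higher number from compound 1 to compound 3 (0.48 log units; beyond the scatter), replaces 4-methyl-3-oxopiperazin-1-yl with 1-isobutylpiperidin-4-yl on an aromatic carbon. Compound 2, which carries 1-methylpiperidin-4-yl and a different aryl end, sits at 0.333 h, the same number as compound 1.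

Compound 4 `CN1CCC(c2ccc3c(c2)oc(=O)n3C(=O)NCCCCc2ccccc2)CC1` is the next step: hydrogen in place of isopropyl on a saturated chain carbon bound to an amine nitrogen in a ring. Going by the values given here, the only step that bears on it is a 3.0-fold higher number from compound 1 to compound 3 (0.48 log units; beyond the scatter), and it changes the whole amine ring, not just the isobutyl, so it does not translate directly. Compound 2, the closest measured compound carrying 1-methylpiperidin-4-yl, gives 0.333 h, a lower number than compound 3. The expectation is therefore a modest downward step, a 2.5-fold lower number from compound 3 to compound 4 (0.40 log units; beyond the scatter), toward the numbers of compound 1 and compound 2 in this assay. Compound 4 is estimated at 0.4 h, with a range from 0.2 h to 0.8 h.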

Compound 4, half-life: 0.833 h
Compound 4: the middle estimate sits 2.1-fold (0.32 log units) below what was measured, and the stated range ends below it.
By their numbers in this assay, from the lowest: compounds 1 and 2 (each within the scatter of the next); then compounds 4 and 3 (each within the scatter of the next).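

In this assay, shortening isobutyl to methyl on the ring amine does not register (a 1.2-fold lower number from compound 3 to compound 4 (0.08 log units; within the scatter)), so this position accepts both groups without a change beyond the scatter, and the isobutyl group is not needed for the higher number. The step from the 4-methyl-3-oxopiperazin-1-yl compound now holds with 1-methylpiperidin-4-yl as well (a 2.5-fold higher number from compound 1 to compound 4 (0.40 log units; beyond the scatter)), while the low number of the fluoro compound separates from its amine group, since removing fluoro alone gives a step beyond the scatter (a 2.5-fold higher number from compound 2 to compound 4 (0.40 log units; beyond the scatter)). Nothing shown accounts for either step, and no measurement here gives a reason for them.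

Open, as far as these compounds go, is whether the fluoro step carries over to the 1-isobutylpiperidin-4-yl compounds, as it rests on a single pair with 1-methylpiperidin-4-yl. Also open, from the compounds shown here alone, is how far this position stays flat in this assay with a benzyl group or a carboxylic acid on a chain at the ring amine, and whether chloro or methoxy in place of fluoro on the aromatic carbon gives a step of the same size.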